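Fluoro to hydrogen on the aromatic ring: clearance notes

The source may hold more compounds than are shown below. What is called first, only, known or untested is meant among the compounds shown, and "the series" means these compounds.

Four compounds share one side chain and differ in core and in one aromatic substituent. Compound 1 is `O=C(NCc1cc(Cl)ccc1-n1cnnn1)[C@@H]1CC=NN1C(=O)[C@H](O)c1ccccc1F`; compound 2 is `O=C(NCc1cc(Cl)ccc1-n1cnnn1)[C@@H]1CC=NN1C(=O)[C@H](O)c1ccccc1`; compound 3 is `O=C(NCc1cc(Cl)ccc1-n1cnnn1)[C@@H]1C[C@@H]2C[C@@H]2N1C(=O)[C@H](O)c1ccccc1F`; compound 4 is `O=C(NCc1cc(Cl)ccc1-n1cnnn1)[C@@H]1C[C@@H]2C[C@@H]2N1C(=O)[C@H](O)c1ccccc1` and is not yet measured. In an ADME assay on liver for metabolic stability, with Liver microsome (Homo sapiens) as the target, read by LC-MS, using microsomes (on this read-out lower numbers stand for slow clearance and higher numbers for fast clearance), compound 1 gives 16 mL.min-1.g-1. For compound 2 the read-out in this assay is a limit of the assay, < 12 mL.min-1.g-1. For compound 3 the read-out in this assay is likewise a limit of the assay, < 12 mL.min-1.g-1. How the core of compound 1 differs from the core of compound 3 is not broken down here.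

The change from compound 1 to compound 2 is hydrogen in place of fluoro on an aromatic carbon. It gave an at least 1.3-fold lower number from compound 1 to compound 2 (0.12 log units; that floor lies within the scatter). The change from compound 3 to compound 4 is hydrogen in place of fluoro on an aromatic carbon, the same change at the same place. Since two of the three values sit at the limit of < 12 mL.min-1.g-1 in this assay, at which 2 of the 3 values shown sit, the measured step is known only as a floor.

Resting on an at least 1.3-fold lower number from compound 1 to compound 2 (0.12 log units; that floor lies within the scatter), the same change on the second core is expected to give a step that the limit leaves unreadable from compound 3 to compound 4. Compound 4 is therefore estimated at 8 mL.min-1.g-1 in this assay, with a good chance that only a limit is reported.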

Compound 4, intrinsic clearance in microsomes: < 16 mL.min-1.g-1
Compound 4: only a limit was reported; the forecaster's own chance of this, stated with the estimate: 80%; the middle value lies beyond the limit too.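

No step can be read between compound 3 and compound 4: each carries only a limit of the assay. On these data alone, what the change from 2-fluorophenyl to phenyl does to intrinsic clearance in microsomes on the core of compound 3 stays open, as does whether it matches the step on the core of compound 1, itself known only as a floor.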